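The source may hold more compounds than are shown below. What is called first, only, known or untested is meant among the compounds shown, and "the series" means these compounds.

Compound 3 `C[C@@H](O)[C@H]1C(=O)N2C(C(=O)OCOC(=O)O[C@H]3CCCCc4ccccc43)=C(S[C@@H]3CN[C@H](C(=O)N(C)C)C3)[C@H](C)[C@H]12` gives the highest number among the three compounds whose half-lives are shown in a physicochemical assay for metabolic stability, read by HPLC, at pH 7.4, tested at 100 uM; on this read-out lower numbers stand for a shorter-lived compound and higher numbers for a longer-lived compound. Its nearest neighbour is compound 2 `C[C@@H](O)[C@H]1C(=O)N2C(C(=O)OCOC(=O)O[C@@H]3CCCc4ccccc43)=C(S[C@@H]3CN[C@H](C(=O)N(C)C)C3)[C@H](C)[C@H]12`, which in this assay gives 0.025 h, while compound 3 itself gives 0.467 h, so that a 19-fold higher number from compound 2 to compound 3 (1.27 log units; beyond the scatter). Compound 1 `C[C@@H](O)[C@H]1C(=O)N2C(C(=O)OCOC(=O)O[C@@H]3CCc4ccccc43)=C(S[C@@H]3CN[C@H](C(=O)N(C)C)C3)[C@H](C)[C@H]12` reaches only the limit of this assay, < 0.0167 h, which is a limit and not a number. Between compounds 1 and 2 the record shows an at least 1.4-fold higher number from compound 1 to compound 2 (0.17 log units; that floor lies within the scatter), and between compounds 1 and 3 it shows an at least 27-fold higher number from compound 1 to compound 3 (1.44 log units; beyond the scatter).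

Compound 4 `C[C@@H](O)[C@H]1C(=O)N2C(C(=O)OCOC(=O)O[C@H]3CCc4ccccc43)=C(S[C@@H]3CN[C@H](C(=O)N(C)C)C3)[C@H](C)[C@H]12` is the next step from compound 3: a group of 9 heavy atoms (9 carbon; one five-membered non-aromatic ring of carbon only, one six-membered aromatic ring of carbon only) in place of a group of 11 heavy atoms (11 carbon; one six-membered aromatic ring of carbon only, one seven-membered non-aromatic ring of carbon only), on an oxygen next to a carbonyl group. This is the reverse of the change from compound 1 to compound 3, with the 2,3-dihydro-1H-inden-1-yl group carrying the other defined stereocentre. Going by the values given here, the only measured step that bears on it is that from compound 1 to compound 3, which was large and beyond the scatter, and the step from compound 2 to compound 3 points the same way. Compound 4 is therefore expected to fall far back in this assay, with a step of a 31-fold lower number from compound 3 to compound 4 (1.49 log units; beyond the scatter), most likely to the limit where compound 1 sits (the limit of < 0.0167 h in this assay, at which 1 of the 3 values shown sits). The half-life of compound 4 is estimated at 0.015 h, within 0.005 h to 0.05 h.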

Compound 4, half-life: < 0.0167 h
Compound 4: a limit, no number; the forecaster's own chance of this, stated with the estimate: 60%; the middle value lies beyond the limit too.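

In this assay compound 4 gives < 0.0167 h, which is a limit and not a number, so the other drawn configuration of the 2,3-dihydro-1H-inden-1-yl group also stays at the limit: the limit of < 0.0167 h in this assay, at which 2 of the 4 values shown sit. With an at least 27-fold lower number from compound 3 to compound 4 (1.44 log units; beyond the scatter), the large gap to the seven-membered ring group of compound 3 now holds for both drawn forms of the 2,3-dihydro-1H-inden-1-yl group, whereas an at least 1.4-fold lower number from compound 2 to compound 4 (0.17 log units; that floor lies within the scatter) is only a floor within the scatter and does not set compound 4 apart from compound 2. The step between the two drawn configurations cannot be read, since both of its ends are limits, and any difference between them stays hidden: the fact that compounds 1 and 4 differ only in the configuration as drawn.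

The compounds shown leave open whether the higher half-life belongs to the seven-membered ring group of compound 3 alone, whether an eight-membered carbon ring would go further, and whether the other drawn configuration of the seven-membered ring group would give the same half-life. They also leave open how a cyclohexyl group or an open-chain n-hexyl group, neither with an aromatic ring, would behave on the same oxygen.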